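Notes on the series: compound 1 to compound 4

A few compounds are considered here, and "the series" means these few. Any claim that something is new, unique, unknown or untested is made for them only; others in the source may bear on it.

Measured in a functional assay on L1210 cells (Mus musculus) for inhibition; on this read-out lower numbers stand for stronger inhibition and higher numbers for weaker inhibition:
compound 1 `COC(=O)CNc1ncnc2c1C(=O)C(OC)=CC2=O`: 1.2 ug/mL
compound 2 `COC(=O)C(Nc1ncnc2c1C(=O)C(OC)=CC2=O)C(C)C`: 0.825 ug/mL
compound 3 `COC1=CC(=O)c2ncnc(NCCCn3cnc4c(N)ncnc43)c2C1=O`: > 10 ug/mL (a limit, not a number)

Among the measured compounds shown here, compound 1 (1.2 ug/mL) and compound 2 (0.825 ug/mL) lie within the scatter of each other, so compound 1 sits level with the only other number in the set. Compound 3 gives only a limit.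

Still to be measured is compound 4 `COC1=CC(=O)c2ncnc(NCCN(C)C)c2C1=O`, which differs from compound 1 as follows: (dimethylamino)methyl in place of methoxycarbonyl on a saturated chain carbon bound to a nitrogen on an aromatic ring (in words, (dimethylamino)methyl in place of methoxycarbonyl on a saturated chain carbon bound to a nitrogen on an aromatic ring).

For the measured compounds named here, the one measured step at that chain carbon, a 1.5-fold lower number from compound 1 to compound 2 (0.16 log units; within the scatter), stays within the scatter, but it keeps the methoxycarbonyl. The exchange itself has not been measured, so guidance is thin. On these data alone, no step beyond the scatter is expected in this assay, and the direction stays open. The expected step is a 1.3-fold higher number from compound 1 to compound 4 (0.10 log units; within the scatter) in the estimate. Compound 3 stands only at a limit (the limit of > 10 ug/mL in this assay, at which 1 of the 3 values shown sits), so the expected range stays wide on the upper side. For compound 4 the estimate is 1.5 ug/mL (expected range 0.4 ug/mL to 6 ug/mL).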

Compound 4, half-maximal inhibitory concentration: 0.316 ug/mL
Beside the measured number, compound 4's estimate is 4.7-fold (0.68 log units) above it; measured number outside the range, below it.
By their numbers in this assay, from the lowest: compound 4; then compounds 2 and 1 (each within the scatter of the next). At a limit, above all of these: compound 3.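

In this assay, the exchange of methoxycarbonyl for (dimethylamino)methyl on a saturated chain carbon bound to a nitrogen on an aromatic ring moves the read-out beyond the scatter: a 3.8-fold lower number from compound 1 to compound 4 (0.58 log units; beyond the scatter). The earlier step at this chain carbon, a 1.5-fold lower number from compound 1 to compound 2 (0.16 log units; within the scatter), kept the methoxycarbonyl and stayed within the scatter, so the series had shown no response at this position until now. The methoxycarbonyl is therefore not required for inhibition on this read-out, since compound 4 lacks it and still gives a modest gain over compound 1, though this rests on a single exchange in a single assay.

Compound 3 gives a limit and not a number, so no step involving it can be read: the limit of > 10 ug/mL in this assay, at which 1 of the 4 values shown sits. What the compounds shown leave open is whether the gain goes with the dimethylamino nitrogen or simply with the loss of methoxycarbonyl, a question that a carboxylic acid, a primary amine or a longer chain such as 3-(dimethylamino)propyl on the same core would help to settle.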